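Dimethoxyphenyl swap on the bromoacrylamide series

This account rests on a few compounds, and the source may have more. Where it says the series, first, only, none or still open, it means among the compounds named here.

In a functional assay on L1210 cells (Mus musculus) for inhibition, read by cell counting, with a stated time of 2 days (on this read-out higher numbers stand for weaker inhibition and lower numbers for stronger inhibition), compound 1 `C=C(Br)C(=O)Nc1cccc(-c2cn3nc(-c4ccccc4)sc3n2)c1` gives 600 nM, the lowest of the two numbers in hand. Compound 2 `Nc1cccc(-c2cn3nc(Cc4ccc(Cl)cc4)sc3n2)c1` gives 16000 nM, a higher number, and the gap to compound 1 lies beyond the scatter. Compound 3 `COc1cccc(-c2nn3cc(-c4cccc(N)c4)nc3s2)c1` returns only a limit of the assay, > 250000 nM. the limit of > 250000 nM in this assay, at which 1 of the 3 values shown sits. No pair of these compounds differs in one place, so no measured step is available to guide the next change. Compound 4 `C=C(Br)C(=O)Nc1cccc(-c2cn3nc(-c4ccc(OC)c(OC)c4)sc3n2)c1` keeps the bromoacrylamide of compound 1 and carries 3,4-dimethoxyphenyl in place of phenyl on an aromatic carbon, 3,4-dimethoxyphenyl in place of phenyl on an aromatic carbon. The expected step of a 1.7-fold higher number from compound 1 to compound 4 (0.22 log units; within the scatter) is small, within the scatter or slightly toward a higher number. Compound 4 is estimated at 1000 nM, between 300 nM and 4000 nM.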

Compound 4, half-maximal inhibitory concentration: 42 nM
For compound 4 the middle estimate is 24-fold (1.38 log units) above the measured one; the measured number lies below the stated range.
By their numbers in this assay, from the lowest: compound 4; then compound 1; then compound 2. At a limit, above all of these: compound 3.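

On the aromatic carbon of the five-membered ring, this position turns out to be highly sensitive to the aryl group in the bromoacrylamide series: in this assay 3,4-dimethoxyphenyl in place of phenyl gives a 14-fold lower number from compound 1 to compound 4 (1.15 log units; beyond the scatter). Among these compounds, the earlier compounds offered no single-place step, so this is the first measured reading of the position, and it rests on one pair. No measured property at hand bears on the cause of this step.

Still open, on these data alone, is whether a single methoxy group would carry the same gain, or whether a hydroxyl group or a morpholine ring on that phenyl would hold it.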